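The source may report more compounds than this note shows. Statements on the series, on what has been measured and on what is new or still open speak of the compounds shown alone.

Measured so far in a physicochemical assay for lipophilicity; on this read-out lower numbers stand for lower lipophilicity and higher numbers for higher lipophilicity:

Compound 1, `C[n+]1ccn(CCCNS(=O)(=O)C(F)(F)F)c1/C=N/O`, gives -1.26.
Compound 2, `CCN(CCCn1cc[n+](C)c1/C=N/O)S(=O)(=O)C(F)(F)F`, gives -1.02.
Compound 3, `C[n+]1ccn(CCNS(=O)(=O)c2ccccc2)c1/C=N/O`, gives -1.92.

Compounds 1 and 2 differ in one place, (ethyl in place of hydrogen on a sulfonamide nitrogen), and in this assay this change gave a number 0.24 log units higher from compound 1 to compound 2 (within the scatter). Compound 3 has the lowest number of the three; its neighbours are compound 1 and then compound 2, both beyond the scatter. How the core of compound 3 differs from the core of compound 1 is not broken down here.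

Compound 4, `CCN(CCn1cc[n+](C)c1/C=N/O)S(=O)(=O)c1ccccc1`, has not yet been measured. It differs from compound 3 by ethyl in place of hydrogen on a sulfonamide nitrogen, the same change that led from compound 1 to compound 2, since the place is the same in both pairs. Because a number 0.24 log units higher from compound 1 to compound 2 (within the scatter), a like step is expected here, namely a number 0.24 log units higher from compound 3 to compound 4 (within the scatter). Compound 4 is therefore estimated at -1.68 in this assay, most likely between -2 and -1.35, resting on one earlier pair only.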

Compound 4, distribution coefficient: -1.39
The estimate for compound 4 lay 0.29 log units below the measured number; low and high end bracket the measured number.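

In this assay, putting ethyl in place of hydrogen on a sulfonamide nitrogen gave a number 0.53 log units higher from compound 3 to compound 4 (beyond the scatter), while the same change on the other core gave a number 0.24 log units higher from compound 1 to compound 2 (within the scatter), so both pairs point the same way. For the compounds shown here, this does not show that the change adds a fixed amount on any core: only the step on the core of compound 3 lies beyond the usual scatter, and two pairs are too few to establish a rule for the series. Nothing given here explains how the two steps came to differ in this way.

Going by these compounds, it remains open whether methyl or propyl on the same sulfonamide nitrogen would shift the number in the same direction as ethyl. It is also unknown whether the ethyl step would hold on a core carrying a longer chain or an amine, since these two pairs cover only the cores of compound 1 and compound 3.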